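Compound 3 to compound 4: a 1H-pyrrol-2-yl exchange

The source may report more compounds than this note shows. Statements on the series, on what has been measured and on what is new or still open speak of the compounds shown alone.

In a functional assay on DU-145 cells (Homo sapiens) for inhibition, read by trypan blue exclusion, with a stated time of 96 h (a higher number here means a weaker inhibitor of growth, a lower number a stronger inhibitor of growth), compound 3 `CN(C)c1ccc(/C=C(/SCc2ccc(Cl)cc2)C(=O)c2ccc(Cl)cc2)cc1` gives > 100000 nM as a limit of the assay and not a number. It therefore has no measured position, and the series holds the limit of > 100000 nM in this assay, at which 1 of the 3 values shown sits, as its only such case.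

Compound 4 `O=C(/C(=C\c1ccc[nH]1)SCc1ccc(Cl)cc1)c1ccc(Cl)cc1` is reached by 1H-pyrrol-2-yl in place of 4-(dimethylamino)phenyl on a double-bonded chain carbon bound to a double-bonded chain carbon and the change sits on a double-bonded chain carbon bound to a double-bonded chain carbon.

For the measured compounds named here, three measured steps bear on this place. Compound 1 `Cc1ccsc1/C=C(/SCc1ccc(Cl)cc1)C(=O)c1ccc(Cl)cc1` with 3-methylthiophen-2-yl gives 50000 nM and compound 2 `O=C(/C(=C\c1ccc(Br)cc1)SCc1ccc(Cl)cc1)c1ccc(Cl)cc1` with 4-bromophenyl gives 1000 nM in this assay readings. Both a 50-fold lower number from compound 1 to compound 2 (1.70 log units; beyond the scatter) and an at least 100-fold higher number from compound 2 to compound 3 (2.00 log units; beyond the scatter) are large, whereas an at least 2.0-fold higher number from compound 1 to compound 3 (0.30 log units; that floor lies within the scatter) shows no separation beyond the scatter.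

Of these groups, 3-methylthiophen-2-yl is the nearest to 1H-pyrrol-2-yl, so compound 1 at 50000 nM is the better guide, and the large gain in a 50-fold lower number from compound 1 to compound 2 (1.70 log units; beyond the scatter) is not expected to carry over. A moderate move to a lower number is expected, given as an at least 3.3-fold lower number from compound 3 to compound 4 (0.52 log units; beyond the scatter) and estimated only loosely, as its starting point is a limit. The estimate for compound 4 is 30000 nM with an expected range from 6000 nM to 100000 nM in this assay readings.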

Compound 4, concentration for 50% growth inhibition: 10000 nM
Beside the measured number, compound 4's estimate is 3.0-fold (0.48 log units) above it; low and high end bracket the measured number.
By their numbers in this assay, from the lowest: compound 2; then compound 4; then compound 1. At a limit, above all of these: compound 3.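

Compound 3 is held only as a limit of the assay and not as a number: the limit of > 100000 nM in this assay, at which 1 of the 4 values shown sits.

In this assay, 1H-pyrrol-2-yl, the only group shown at this place with a hydrogen-bond donor, gives a measured value, and an at least 10-fold lower number from compound 3 to compound 4 (1.00 log units; beyond the scatter) is therefore a floor on the step and not its size. The position now also separates 1H-pyrrol-2-yl from 3-methylthiophen-2-yl, with a 5.0-fold lower number from compound 1 to compound 4 (0.70 log units; beyond the scatter), while 4-bromophenyl still gives the lowest number of the series, with a 10-fold higher number from compound 2 to compound 4 (1.00 log units; beyond the scatter).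

The compounds shown leave open whether the step from 3-methylthiophen-2-yl to 1H-pyrrol-2-yl goes with the hydrogen-bond donor, the ring hetero atom or the loss of the methyl; 1-methyl-1H-pyrrol-2-yl and unsubstituted thiophen-2-yl at this place would pull these apart. Also open, on these data alone, is how far the wide span between 4-bromophenyl and 4-(dimethylamino)phenyl depends on the group on the phenyl ring, which 4-chlorophenyl, 4-methoxyphenyl or unsubstituted phenyl would help to settle.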